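A few compounds are considered here, and "the series" means these few. Any claim that something is new, unique, unknown or untested is made for them only; others in the source may bear on it.

Measured so far in a functional assay on PC-9 cells (Homo sapiens) for antiproliferative activity, read by MTT assay, with a stated time of 72 h; a lower number here means a stronger inhibitor, a higher number a weaker inhibitor 

Compound 1 `O=C(O)CCC(=O)Nc1cc(Nc2ccc(Cl)cc2)ncn1` gives 790 nM 
Compound 2 `COc1ccc(OC)c(Nc2cc(Nc3ccc(F)cc3)ncn2)c1` gives 640 nM 

Compound 2 stands at 640 nM and so lies within the scatter of compound 1 at 790 nM in this pair of values. Neither compound can be placed ahead of the other.

Compound 3 `COc1ccc(OC)c(Nc2cc(Nc3ccc(N4CCN(C)CC4)cc3)ncn2)c1` differs from compound 2 in one place: 4-methylpiperazin-1-yl in place of fluoro on an aromatic carbon with 4-methylpiperazin-1-yl in place of fluoro on an aromatic carbon, para to a large group.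

Among the measured compounds shown here, the two measured compounds differ in more than one place, so the data hold no measured step for this change and give no direct guide to its size. A modest move to a lower number in this assay is expected, only a little beyond the scatter, and a move the other way cannot be ruled out. The expected step is a 2.3-fold lower number from compound 2 to compound 3 (0.36 log units; beyond the scatter) and it carries wide uncertainty. For compound 3 the estimate is 280 nM with an expected range from 70 nM to 1100 nM as the upper end.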

Compound 3, half-maximal inhibitory concentration: > 30000 nM
Compound 3: only a limit was reported (the forecaster's own chance of this, stated with the estimate: 5%); at least 100-fold (2.02 log units) between middle value and limit.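

In this assay compound 3 gives > 30000 nM, which is a limit of the assay and not a number. Placing 4-methylpiperazin-1-yl in place of fluoro on an aromatic carbon, para to a large group, is the only single-place change shown so far, and it reads as an at least 46-fold higher number from compound 2 to compound 3 (1.67 log units; beyond the scatter), so this position does not tolerate every group and the activity held by compound 2 does not survive this exchange. The upper end of that step stays unknown, and compound 3 gives no ranking among inactive analogues, as the reading stops at the top of the range: the limit of > 30000 nM in this assay, at which 1 of the 3 values shown sits.

The compounds shown leave open whether the loss follows the saturated ring, its nitrogen atoms or simply the larger group, and a morpholine, a dimethylamino group or a methoxy on the same carbon would help to separate these readings. Also open, going by these compounds, is whether 4-methylpiperazin-1-yl would have the same effect on a compound carrying the side chain of compound 1, which ends in a carboxylic acid, in place of the substituted aniline of compound 2.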